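The source may hold more compounds than are shown below. What is called first, only, known or untested is meant among the compounds shown, and "the series" means these compounds.

Measured compounds:

compound 1, `COc1ccc(CNC(=O)/C(C#N)=C/c2ccc[nH]2)cc1`, in a functional assay on SJ-G2 cells (Homo sapiens) for inhibition, read by MTT assay, with a stated time of 72 h (on this read-out lower numbers stand for stronger inhibition of growth and higher numbers for weaker inhibition of growth), compound 1 gives > 50000 nM

compound 2, `N#C/C(=C\c1ccc[nH]1)C(=O)NCc1ccc(Cl)c(Cl)c1`, in this assay compound 2 gives > 50000 nM

compound 3, `COc1ccc(CNC(=O)/C(C#N)=C/c2ccco2)cc1`, in this assay compound 3 gives 31000 nM

The value of compound 1 is a limit of this assay, not a number. The value of compound 2 is likewise a limit, so that two of the three measured values sit at the limit of > 50000 nM in this assay, at which 2 of the 3 values shown sit. Compound 3 is the only one of the three with a number. The change from compound 1 to compound 3 is furan-2-yl in place of 1H-pyrrol-2-yl on a double-bonded chain carbon bound to a double-bonded chain carbon, and it gave an at least 1.6-fold lower number from compound 1 to compound 3 (0.20 log units; that floor lies within the scatter).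

How the core of compound 2 differs from the core of compound 1 is not broken down here.

Compound 4, `N#C/C(=C\c1ccco1)C(=O)NCc1ccc(Cl)c(Cl)c1`, has not been measured in this assay. It arises from compound 2 by furan-2-yl in place of 1H-pyrrol-2-yl on a double-bonded chain carbon bound to a double-bonded chain carbon, the same change that turns compound 1 into compound 3. Because compound 3 gave 31000 nM, the step from compound 2 to compound 4 is expected to be about an at least 1.4-fold lower number from compound 2 to compound 4 (0.15 log units; that floor lies within the scatter). Compound 2 itself sits at a limit, so there is a real chance that only a limit is reported again for compound 4. The estimate for compound 4 in this assay is 35000 nM, between 15000 nM and 80000 nM.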

Compound 4, concentration for 50% growth inhibition: > 50000 nM
Compound 4: only a limit was reported; the forecaster's own chance of this, stated with the estimate: 40%; at least 1.4-fold (0.15 log units) between middle value and limit.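

Compound 2 and compound 4 both sit at a limit of the assay, not at a number, so no step can be read from the exchange of 1H-pyrrol-2-yl for furan-2-yl between them: the limit of > 50000 nM in this assay, at which 3 of the 4 values shown sit.

The compounds shown leave open whether the same exchange, which links compound 1 to compound 3, changes growth inhibition at all when it links compound 2 to compound 4.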